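The source may hold more compounds than are shown below. What is called first, only, known or untested is meant among the compounds shown, and "the series" means these compounds.

Compound 1 `O=C1/C(=C/c2ccccc2)CCc2ccccc21` is the parent of the first pair; in a functional assay on L1210 cells (Mus musculus) for inhibition (on this read-out higher numbers stand for weaker inhibition and lower numbers for stronger inhibition), compound 1 gives 121000 nM. Compound 2 `O=C1/C(=C/c2ccc(F)cc2)CCc2ccccc21` carries fluoro in place of hydrogen on an aromatic carbon, and in this assay compound 2 gives 49300 nM; the step is a 2.5-fold lower number from compound 1 to compound 2 (0.39 log units; beyond the scatter). Compound 3 `O=C1CCCCC/C1=C\c1ccccc1` rests on another core; the difference between the two cores is not broken down here. In this assay, going by the values given here, compound 3 gives 261000 nM, the highest of the three numbers measured so far. Compound 4 `O=C1CCCCC/C1=C\c1cccc(F)c1` is not yet measured; against compound 3 it carries fluoro in place of hydrogen on an aromatic carbon. Among the compounds with values here, this is the same kind of change as the one from compound 1 to compound 2, not the same: in compound 2 the fluoro sits para to a large group, in compound 4 it sits meta to a group of 9 heavy atoms, and the core is different. The change has been seen once, as a 2.5-fold lower number from compound 1 to compound 2 (0.39 log units; beyond the scatter). Within the data shown here, a step of a 1.9-fold lower number from compound 3 to compound 4 (0.27 log units; within the scatter) is expected because the single earlier instance gave a 2.5-fold lower number from compound 1 to compound 2 (0.39 log units; beyond the scatter), with the shift in place and core leaving room for a smaller effect. Compound 4 is expected to give about 140000 nM in this assay, between 60000 nM and 330000 nM.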

Compound 4, half-maximal inhibitory concentration: 382000 nM
Beside the measured number, compound 4's estimate is 2.7-fold (0.44 log units) below it; the measured number lies above the stated range.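

In this assay, fluoro in place of hydrogen on an aromatic carbon does not carry over unchanged from one core to the other: the same change on two cores in this assay, a 2.5-fold lower number (0.39 log units; beyond the scatter) from compound 1 to compound 2 and a 1.5-fold higher number (0.17 log units; within the scatter) from compound 3 to compound 4, 3.6-fold (0.56 log units) apart, beyond the scatter of two such steps

The new step, a 1.5-fold higher number from compound 3 to compound 4 (0.17 log units; within the scatter), leaves the two numbers unseparated, so the lower number seen on the first core does not recur on the second. The two pairs differ in both the core and the place of the fluoro, with compound 4 carrying it meta to a group of 9 heavy atoms, so the data do not show which of the two separates the steps, and a single pair on each core gives no rule for the series.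

Left open is how fluoro behaves on the core of compound 1 at the place it holds in compound 4, and on the core of compound 3 at the place it holds in compound 2. Also open, going by these compounds, is whether other groups on the aromatic ring, such as chloro, methoxy or an amine, follow either step.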